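Three Non-Toxic Analogues and a Fourth to Be Tested

The compounds below may be only part of what the source reports. "The series", "measured", "known", "first", "only" and "open" are said of these compounds alone.

The study compares closely related compounds in an ADME assay on MT4 cells (Homo sapiens) for cytotoxicity, read by MTT assay, with a stated time of 96 h; on this read-out higher numbers stand for lower toxicity in this test and lower numbers for higher toxicity in this test. Compound 1 `Cc1ccc(NCc2cn(-c3ccccc3)nc2-c2ccc(C(F)(F)F)cc2)cc1` is one of them. In this assay compound 1 gives > 100000 nM, which is a limit of the assay rather than a number. Compound 2 `Brc1ccc(NCc2cn(-c3ccccc3)nc2-c2ccc(Br)cc2)cc1` was tested under the same conditions. In this assay compound 2 likewise reaches only the limit > 100000 nM. Compound 3 `Cc1ccc(NCc2cn(-c3ccccc3)nc2-c2ccc(Br)cc2)cc1` completes the measured set. In this assay compound 3 also stops at the limit > 100000 nM.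

Compound 1 and compound 3 differ by trifluoromethyl in place of bromo on an aromatic carbon. The resulting step, a step that the two limits leave unreadable from compound 3 to compound 1, cannot be sized because both values are limits. The cores of compound 2 and compound 3 differ by bromo in place of methyl on an aromatic carbon, and here too the step that the two limits leave unreadable from compound 2 to compound 3 is not readable. All that the three values show is that none of the compounds reached a measurable cytotoxic concentration, a point summarised by the limit of > 100000 nM in this assay, at which 3 of the 3 values shown sit.

Compound 4 `FC(F)(F)c1ccc(-c2nn(-c3ccccc3)cc2CNc2ccc(Br)cc2)cc1` has not yet been measured. It differs from compound 2 by trifluoromethyl in place of bromo on an aromatic carbon, the same change, at the same place, as that from compound 3 to compound 1. Because (the limit of > 100000 nM in this assay, at which 3 of the 3 values shown sit), compound 4 is expected to sit at the limit as well. Compound 4 is therefore estimated at 150000 nM in this assay, with a range from 80000 nM to 400000 nM. The expected step is a step that the limit leaves unreadable from compound 2 to compound 4, essentially no change.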

Compound 4, half-maximal cytotoxic concentration: > 100000 nM
Compound 4 gave a limit, no number (the forecaster's own chance of this, stated with the estimate: 85%); the middle value does not contradict the limit.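

In this assay compound 4 gives > 100000 nM as a limit of the assay and not a number. No new step can be read, since the steps linking compound 4 to compound 2 and to compound 1 join limits only: the limit of > 100000 nM in this assay, at which 4 of the 4 values shown sit. The compounds shown leave open how large the cytotoxic concentration of any of them is, and whether trifluoromethyl, bromo or methyl on an aromatic carbon changes it at all.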